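Oxime ether series: expectation for compound 4

A few compounds are considered here, and "the series" means these few. Any claim that something is new, unique, unknown or untested is made for them only; others in the source may bear on it.

Measured so far, all in an assay on HepG2 cells for agonist activity at nuclear receptor subfamily 1 group I member 3 (Homo sapiens), read by a luciferase reporter, with a stated time of 23 h; on this read-out lower numbers stand for an effect already at smaller amounts and higher numbers for an effect only at larger amounts of compound:
- compound 1 `FC(F)(F)c1ccc(CO/N=C/c2c(-c3ccc4ccccc4c3)nc3occn23)cc1` gives 470 nM
- compound 2 `CC(C)(C)c1ccc(CO/N=C/c2c(-c3ccc4ccccc4c3)nc3occn23)cc1` gives 7900 nM
- compound 3 `Clc1ccc(CO/N=C/c2c(-c3cccc4ccccc34)nc3sccn23)cc1Cl` gives 940 nM

Within this set, compound 3 and compound 1 give values that lie within the scatter of each other, while compound 2 gives a clearly higher number than compound 3. Going by the values given here, the only single-point change with a measured outcome is a 17-fold higher number from compound 1 to compound 2 (1.23 log units; beyond the scatter), and it concerns the substituent on the benzyl group, not the aryl group on the shared core.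

Compound 4 `COc1ccc(-c2nc3sccn3c2/C=N/OCc2ccc(Cl)c(Cl)c2)cc1` differs from compound 3 at the aryl group on the core: 4-methoxyphenyl in place of naphthalen-1-yl on an aromatic carbon. Among the compounds with values here, no measured pair changes that group, so no step bears directly on this change. Within the data shown here, the only reference is the value of compound 3 itself, and the expectation for compound 4 therefore rests on the value of compound 3 with a wide margin on either side.

Compound 4 is estimated at 2000 nM in this assay, with a range from 500 nM to 8000 nM, meaning an expected step of a 2.1-fold higher number from compound 3 to compound 4 (0.33 log units; beyond the scatter).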

Compound 4, half-maximal effective concentration: 490 nM
Compound 4: the middle estimate sits 4.1-fold (0.61 log units) above what was measured; measured number below the stated range.
By their numbers in this assay, from the lowest: compounds 1, 4 and 3 (each within the scatter of the next); then compound 2.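

Going by these compounds alone, replacing naphthalen-1-yl with 4-methoxyphenyl on this aromatic carbon of the shared core gives, in this assay, a 1.9-fold lower number from compound 3 to compound 4 (0.28 log units; within the scatter) and is the first measured step at this position. With the benzyl group held the same, a single six-membered aromatic ring of carbon only, carrying a methoxy group, therefore reads the same within the scatter as the two-ring naphthalen-1-yl, so the second ring is not required for a value in this range. No supporting data are available to account for this outcome.

Open, as far as these compounds go, is whether this position stays as permissive with an amine, a carboxylic acid or a longer alkoxy chain in place of the methoxy group. Also open, from the compounds shown here alone, is whether 4-methoxyphenyl gives the same outcome alongside the trifluoromethyl and tert-butyl benzyl groups on the core of compound 1.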